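Cytotoxicity of a Carboxamide Series and a Cyclised Amide

The compounds below may be only part of what the source reports. "The series", "measured", "known", "first", "only" and "open" are said of these compounds alone.

Compound 1 `CC(C)n1ncc2c(C(=O)Nc3cccc(F)c3)cc(-c3cccs3)nc21` gives > 200000 nM in an ADME assay on LLC-MK2 cells (Macaca mulatta) for cytotoxicity, read by spectrophotometry and crystal violet staining, with a stated time of 4 days (on this read-out lower numbers stand for higher toxicity in this test and higher numbers for lower toxicity in this test), a limit of the test rather than a number.
Compound 2 `CC(C)n1ncc2c(C(=O)Nc3cccnc3)cc(-c3cccs3)nc21` gives > 200000 nM in this assay, again a limit.
Compound 3 `CC(C)n1ncc2c(C(=O)Nc3cccc(F)c3F)cc(-c3cccs3)nc21` gives 75000 nM in this assay.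

Compound 3 thus stands as the only number shown; the other two values sit at the upper limit of the test (the limit of > 200000 nM in this assay, at which 2 of the 3 values shown sit). All three compounds share one core and differ only in the group attached to the amide-type nitrogen. Among the compounds with values here, the step of an at least 2.6-fold lower number from compound 1 to compound 3 (0.42 log units; beyond the scatter) and the step of an at least 2.6-fold lower number from compound 2 to compound 3 (0.42 log units; beyond the scatter) each run from a limit down to the one measured number, so both show a fall of at least that size when the 2,3-difluorophenyl group is present.

Compound 4 `CC(C)n1ncc2c(C(=O)N3CCc4cccnc43)cc(-c3cccs3)nc21` departs from compound 3 by a group of 9 heavy atoms (7 carbon, 2 nitrogen; one five-membered non-aromatic ring with 1 hetero atom, one six-membered aromatic ring with 1 hetero atom) in place of a group of 9 heavy atoms (6 carbon, 1 nitrogen, 2 fluorine; one six-membered aromatic ring of carbon only), on a carbonyl carbon. The entering group removes the hydrogen-bond donor and brings a six-membered aromatic ring with one hetero atom, a feature shared with the pyridin-3-yl group of compound 2, whose value is a limit. Within the data shown here, the difluorophenyl group that accompanied the only measured number is gone, so the number is expected to rise back toward the limit, an upward step a 2.0-fold higher number from compound 3 to compound 4 (0.30 log units; within the scatter). Compound 4 is therefore estimated at 150000 nM in this assay, within 50000 nM to 400000 nM.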

Compound 4, half-maximal cytotoxic concentration: 50000 nM
Beside the measured number, compound 4's estimate is 3.0-fold (0.48 log units) above it; low and high end bracket the measured number.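

The cyclised group on the carbonyl carbon gives up both the (2,3-difluorophenyl)amino group and the amide hydrogen, yet in this assay the number stays level with that of the difluorinated amide: a 1.5-fold lower number from compound 3 to compound 4 (0.18 log units; within the scatter). A measurable cytotoxic concentration at this position therefore does not depend on the 2,3-difluorophenyl group or on the amide hydrogen, since compound 4 has neither and still lies clearly under the two simple amides, with an at least 4.0-fold lower number from compound 2 to compound 4 (0.60 log units; beyond the scatter) and an at least 4.0-fold lower number from compound 1 to compound 4 (0.60 log units; beyond the scatter). Compound 2 and compound 4 both carry a six-membered aromatic ring with 1 hetero atom, so that ring alone does not keep a compound at the top of the test, and the second, five-membered ring and the missing amide hydrogen are what set compound 4 apart from compound 2.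

The compounds shown cannot separate those two features, and a simple amide of dimethylamine or piperidine on the same carbonyl carbon would lack the amide hydrogen without the fused ring system. How far compound 1 and compound 2 really lie from the others also stays open, as their values are limits and not numbers: the limit of > 200000 nM in this assay, at which 2 of the 4 values shown sit.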